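The source may report more compounds than this note shows. Statements on the series, on what has been measured and on what is new or still open speak of the compounds shown alone.

Measured values in a functional assay on HCT-8 cells (Homo sapiens) for antiproliferative activity, read by MTT assay, with a stated time of 48 h; on this read-out higher numbers stand for weaker inhibition and lower numbers for stronger inhibition
- compound 1 `COc1ccc2c(/C=C/C(=O)c3cc(OC)c(OC)c(SC)c3)c[nH]c2c1` gives 138 nM
- compound 2 `COc1ccc2c(/C=C/C(=O)c3cc(N)c(OC)c(OC)c3)c[nH]c2c1` gives 368 nM
- compound 3 `COc1ccc2c(/C=C/C(=O)c3cc(N)c(OC)c(OC)c3)cn(C)c2c1` gives 455 nM

Of these three, compound 2 has a clearly higher number than compound 1 and cannot be separated from compound 3. The next structure is compound 4 `COc1ccc2c(/C=C/C(=O)c3cc(OC)c(OC)c([N+](=O)[O-])c3)c[nH]c2c1`, which carries nitro in place of amino on an aromatic carbon, ortho to a methoxy group (nitro in place of amino on an aromatic carbon).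

Among the compounds with values here, only one measured step touches this same carbon. Amino in place of methylsulfanyl gave a modest change (a 2.7-fold higher number from compound 1 to compound 2 (0.43 log units; beyond the scatter)), which shows that the number can move with the group at this carbon. The other step, methyl in place of hydrogen on an aromatic nitrogen (a 1.2-fold higher number from compound 2 to compound 3 (0.09 log units; within the scatter)), lies elsewhere and stays within the scatter, so it offers little guidance.

Nitro has not been measured on this core, so neither direction is favoured, and the expectation stays near compound 2 (368 nM). No step beyond the scatter is expected in this assay, and the estimated change is small (a 1.2-fold lower number from compound 2 to compound 4 (0.09 log units; within the scatter)). For compound 4 the estimated value is 300 nM, with an expected range from 80 nM to 1100 nM.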

Compound 4, half-maximal inhibitory concentration: 982 nM
Compound 4: middle estimate off by 3.3-fold (0.51 log units), on the low side; low and high end bracket the measured number.
By their numbers in this assay, from the lowest: compound 1; then compounds 2 and 3 (each within the scatter of the next); then compound 4.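

In this assay, nitro in place of amino gives a clear rise in the number (a 2.7-fold higher number from compound 2 to compound 4 (0.43 log units; beyond the scatter)), so this aromatic carbon has now responded to a second change of group, and amino does not mark the high end of the series. Nitro in place of methylsulfanyl gives the widest step so far at this carbon (a 7.1-fold higher number from compound 1 to compound 4 (0.85 log units; beyond the scatter)), which places the three groups in order from methylsulfanyl through amino to nitro, with each gap beyond the scatter. Nothing measured here accounts for this order.

The compounds shown leave open where a hydroxyl group or a carboxylic acid at this carbon would fall in that order. They also leave open whether methyl on the aromatic nitrogen would still stay within the scatter with nitro or methylsulfanyl in place.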